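This account rests on a few compounds, and the source may have more. Where it says the series, first, only, none or still open, it means among the compounds named here.

Compound 3, with the structure `Nc1nc(-c2cccc(CO)c2)nc2sc(-c3ccco3)nc12`, is one of three measured members of a series built on a shared core. Its two neighbours are compound 1, `Nc1nc(-c2cccc(CO)c2)nc2sc(-c3ccccc3)nc12`, and compound 2, `N#Cc1cccc(-c2nc(N)c3nc(-c4ccccc4)sc3n2)c1`. In a functional assay on CHO cells for antagonist activity at adenosine receptor A2b (Homo sapiens), read by cAMP accumulation, with a stated time of 10 min (a lower number here means a stronger inhibitor, a higher number a weaker inhibitor), compound 1 gives only a limit, > 30000 nM. Compound 2 likewise gives only a limit in this assay, > 30000 nM. Compound 3 too stands at a limit in this assay, > 30000 nM, so its position cannot be placed within the measured range. The two measured steps are therefore unreadable: a step that the two limits leave unreadable from compound 1 to compound 2 and a step that the two limits leave unreadable from compound 1 to compound 3. All three values sit at the same place, namely (the limit of > 30000 nM in this assay, at which 3 of the 3 values shown sit).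

The compound now in question is compound 4, `Nc1nc(-c2cccc(O)c2)nc2sc(-c3ccco3)nc12`. It differs from compound 3 in one respect, (hydroxy in place of hydroxymethyl on an aromatic carbon). Among the compounds with values here, neither measured step bears directly on this change, since both are unreadable, and the only guidance is that every compound made so far sits at the limit of this assay. Compound 4 is therefore expected to remain at or near that limit, with an estimated step of a number no higher from compound 3 to compound 4 (the limit leaves the size open), and its estimated value in this assay is 30000 nM, in the range 8000 nM to 100000 nM. The measurement will show whether this expectation holds.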

Compound 4, half-maximal inhibitory concentration: > 30000 nM
Compound 4: a limit, no number; the forecaster's own chance of this, stated with the estimate: 75%; the middle value sits exactly at the limit.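

In this assay, no size can be read for the change from compound 3 to compound 4, hydroxy in place of hydroxymethyl, as both values are limits and not numbers. The compounds shown leave open how strongly any of them inhibits and whether any of these changes shifts potency, as all sit at one place: the limit of > 30000 nM in this assay, at which 4 of the 4 values shown sit.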